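The compounds below may be only part of what the source reports. "The series", "measured", "known", "first", "only" and "open" are said of these compounds alone.

Values in a functional assay on HeLa cells (Homo sapiens) for antiproliferative activity, read by CCK-8 assay, with a stated time of 72 h; on this read-out lower numbers stand for stronger inhibition and higher numbers for weaker inhibition:
- compound 1 `COc1ccc(-c2cncnc2-c2cc(OC)c(OC)c(OC)c2)cc1`: 1140 nM
- compound 2 `CCOC(=O)Oc1cc(-c2cncnc2-c2cc(OC)c(OC)c(OC)c2)ccc1OC`: 650 nM
- compound 3 `COc1ccc(-c2cncnc2-c2cc(OC)c(OC)c(OC)c2)cc1F`: 500 nM

In this assay compound 3 stands at 500 nM. It cannot be told apart from its nearest neighbour, with a 1.3-fold lower number from compound 2 to compound 3 (0.11 log units; within the scatter).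

Compound 4 `COc1ccc(-c2cncnc2-c2cc(OC)c(OC)c(OC)c2)cc1Cl` carries chloro in place of fluoro on an aromatic carbon, ortho to a methoxy group (chloro in place of fluoro on an aromatic carbon).

No swap of one halogen for another has been measured. Among the measured compounds shown here, the only step at this position is the modest one of fluoro in place of hydrogen, a 2.3-fold lower number from compound 1 to compound 3 (0.36 log units; beyond the scatter). Against that small step, a change beyond the scatter is not expected, and the expected step is a 1.3-fold lower number from compound 3 to compound 4 (0.10 log units; within the scatter). For compound 4 the estimated value is 400 nM, with an expected range from 130 nM to 1200 nM.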

Compound 4, half-maximal inhibitory concentration: 320 nM
For compound 4 the middle estimate is 1.3-fold (0.10 log units) above the measured one; low and high end bracket the measured number.
By their numbers in this assay, from the lowest: compounds 4, 3, 2 and 1 (each within the scatter of the next, the first and the last beyond it).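

Swapping fluoro for chloro on this aromatic carbon, ortho to a methoxy group, gives in this assay a 1.6-fold lower number from compound 3 to compound 4 (0.19 log units; within the scatter) and so leaves the two halogens indistinguishable here. Chloro in place of hydrogen gives a 3.6-fold lower number from compound 1 to compound 4 (0.55 log units; beyond the scatter) and chloro in place of (ethoxycarbonyl)oxy gives a 2.0-fold lower number from compound 2 to compound 4 (0.31 log units; beyond the scatter) as well, a step beyond the scatter that fluoro did not reach against that group. Nothing available accounts for these results.

From the compounds shown here alone, whether bromo or a larger group such as trifluoromethyl would hold the same level at this position remains open. So does the outcome with an amine or a carboxylic acid there.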